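A few compounds are considered here, and "the series" means these few. Any claim that something is new, unique, unknown or untested is made for them only; others in the source may bear on it.

Compound 1 `C=CC(=O)Nc1ccc(-c2nc(Cl)cc(Nc3ccc(C(=O)Nc4ccc(F)cc4)cc3)n2)cc1`: "not determined" (no result reported) in a functional assay on Ramos cells (Homo sapiens) for antiproliferative activity, read by MTT assay, with a stated time of 48 h; on this read-out lower numbers stand for stronger inhibition and higher numbers for weaker inhibition
Compound 2 `C=CC(=O)Nc1ccc(-c2nc(Cl)cc(Nc3ccc(C(=O)Nc4cc(C(F)(F)F)cc(C(F)(F)F)c4)cc3)n2)cc1`: 6180 nM
Compound 3 `C=CC(=O)Nc1ccc(-c2nc(Cl)cc(Nc3ccc(C(=O)Nc4ccc(OC)cc4)cc3)n2)cc1`: "not determined" (no result reported)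

Three measured compounds share the core of compound 1, differing only in the group on the amide carbonyl. Of these, compound 2 alone has a number: in this assay compound 2 gives 6180 nM. Compound 3 stands without a single number in this assay, and compound 1 is a further entry without one, so compound 3 cannot be placed against the others.

Compound 4 `C=CC(=O)Nc1ccc(-c2nc(Cl)cc(Nc3ccc(C(=O)N(CC)CC)cc3)n2)cc1` is the next compound. It differs from compound 3 as follows: diethylamino in place of (4-methoxyphenyl)amino on a carbonyl carbon. Going by the values given here, no step between measured compounds of this kind is recorded, and compound 3 itself has no number, so the size and direction of this step in this assay cannot be read from the data; it could move the read-out either way, or not beyond the scatter at all. With compound 2 giving 6180 nM as the only anchor, compound 4 is expected to sit at about 5000 nM, in a range from 800 nM to 30000 nM.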

Compound 4, half-maximal inhibitory concentration: 11200 nM
Compound 4: middle estimate off by 2.2-fold (0.35 log units), on the low side; the range from low to high includes it.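

Going by these compounds alone, no step from compound 3 to compound 4 can be read in this assay from these results. The compounds shown leave open how diethylamino compares with (4-methoxyphenyl)amino on this carbonyl carbon. Nothing given here bears on the result for compound 4.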